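A few compounds are considered here, and "the series" means these few. Any claim that something is new, unique, unknown or untested is made for them only; others in the source may bear on it.

Compound 1 `N=C(N)c1ccc2[nH]c(-c3cc(F)cc(Br)c3)cc2c1`: in an assay on isolated protein for inhibition of acid-sensing ion channel 3 (Homo sapiens), read by patch clamp, tested at 1 uM (a lower number here means less inhibition, a higher number more inhibition at the concentration tested (going by the name of the read-out)), compound 1 gives 93%.
Compound 2 `COc1cc(F)cc(-c2cc3cc(C(=N)N)ccc3[nH]2)c1`: compound 2 gives 77%.
Compound 3 `N=C(N)c1ccc2[nH]c(-c3cc(F)cc(Cl)c3)cc2c1`: compound 3 gives 82%.

On these numbers compound 3 sits below compound 1, the gap being a number 11 percentage points lower from compound 1 to compound 3 (beyond the scatter), and level with compound 2, since the step of a number 5 percentage points higher from compound 2 to compound 3 (within the scatter) is within the scatter. Compound 4 `N=C(N)c1ccc2[nH]c(-c3cc(N)cc(Cl)c3)cc2c1` differs from compound 3 by amino in place of fluoro on an aromatic carbon. Going by the values given here, no measured step touches the fluoro; the measured steps exchange the other substituent on the same six-membered aromatic ring, and they gave only modest shifts, such as a number 16 percentage points lower from compound 1 to compound 2 (beyond the scatter). Among the compounds with values here, with no direct precedent, only a small step, if any, is expected in this assay, namely a number 7 percentage points lower from compound 3 to compound 4 (within the scatter). Compound 4 is therefore estimated at 75%, with a range from 55% to 92%.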

Compound 4, a percentage reported as inhibition, at one concentration (the size of the read-out at that concentration, not a potency): 78%
Compound 4: the middle estimate sits 3 percentage points below what was measured; low and high end bracket the measured number.
By their numbers in this assay, from the lowest: compounds 2, 4 and 3 (each within the scatter of the next); then compound 1.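

Until now only the other substituent on this ring had changed; here the fluoro itself is exchanged, and amino in place of fluoro gives a number 4 percentage points lower from compound 3 to compound 4 (within the scatter) in this assay. For this pair, then, a group with a hydrogen-bond donor and acceptor stands at this place, meta to a chloro group, with no change beyond the scatter. No measurement here bears on why the number holds.

As far as these compounds go, whether a hydroxy or a methyl group at this place would read the same remains open. So does whether amino would give a similar step with bromo as its partner on the ring.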